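A few compounds are considered here, and "the series" means these few. Any claim that something is new, unique, unknown or untested is made for them only; others in the source may bear on it.

Working notes on the series in a functional assay on the whole organism (strain Sprague-Dawley) for inhibition, with Rattus norvegicus as the target; on this read-out lower numbers stand for an effect already at smaller amounts and higher numbers for an effect only at larger amounts of compound.

The shared core is that of compound 1 `O=c1c(-c2nn[nH]n2)c[nH]c2c(F)cccc12`, which carries fluoro on an aromatic carbon; in this assay compound 1 gives 10 mg/kg. Compound 2 `CS(=O)(=O)c1cccc2c(=O)c(-c3nn[nH]n3)c[nH]c12` carries methylsulfonyl on that carbon instead. In this assay compound 2 gives > 25 mg/kg, which is a limit of the assay and not a number. On the numbers shown, compound 2 stands at the limit of > 25 mg/kg in this assay, at which 1 of the 2 values shown sits, so its distance from compound 1 is known only as an at least 2.5-fold higher number from compound 1 to compound 2 (0.39 log units; beyond the scatter), the one measured step in the series.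

Compound 3 `Cc1cccc2c(=O)c(-c3nn[nH]n3)c[nH]c12` differs from compound 2 by methyl in place of methylsulfonyl on an aromatic carbon. Going by the values given here, no measured step involves methyl at this position, so the only comparison that bears on the change is the one from compound 1 to compound 2, in which methylsulfonyl went with the higher limit. Removing methylsulfonyl is therefore expected to move the number back toward the value of compound 1, though how far is uncertain. For compound 3 the expected step is an at least 1.6-fold lower number from compound 2 to compound 3 (0.22 log units; that floor lies within the scatter). Compound 3 is estimated at 15 mg/kg, with a range from 5 mg/kg to 30 mg/kg.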

Compound 3, minimum effective dose: > 10 mg/kg
Compound 3 ended at the assay's limit (the forecaster's own chance of this, stated with the estimate: 35%); the middle value lies beyond the limit too.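

In this assay compound 2 and compound 3 both sit at limits of the assay and not at numbers, so the size of each step to compound 3 cannot be read, whether from compound 2 or from compound 1. Methyl in place of fluoro on this aromatic carbon gives a number no lower from compound 1 to compound 3 (the limit leaves the size open), so neither methylsulfonyl nor methyl has yet given a number lower than that of compound 1. Taking out methylsulfonyl for methyl, a much smaller group with no hydrogen-bond acceptors, therefore does not bring back a readable number at this position, and fluoro remains the only group here with one.

As far as these compounds go, it stays open whether compound 3 differs from compound 2 at all, and how far either lies from compound 1. From the compounds shown here alone, it also stays open whether any other group on this carbon, such as chloro, an amine or a carboxylic acid, would give a number lower than that of compound 1 or would at least give a number rather than a limit.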